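The compounds below may be only part of what the source reports. "The series", "measured", "known", "first", "only" and "open" are said of these compounds alone.

Values so far in a physicochemical assay for solubility, read by HPLC, at pH 7.4 (a lower number here means a less soluble compound, a higher number a more soluble compound), are these.
Compound 1 `COc1ccc2[nH]c(C)c(Cc3ccccc3)c(=O)c2c1` gives 2000 nM
Compound 2 `Cc1[nH]c2ccc(Cl)cc2c(=O)c1Cc1ccccc1` gives < 2000 nM as a limit of the assay
Compound 3 `COc1ccc2c(c1)c(=O)c(Cc1ccccc1)c(C)n2C` gives 10000 nM

Among the compounds with values here, only two of these readings are actual numbers, and the higher belongs to compound 3 (10000 nM). The nearest is that of compound 1, and the gap is a 5.0-fold higher number from compound 1 to compound 3 (0.70 log units; beyond the scatter) with methyl in place of hydrogen on an aromatic nitrogen. Compound 2 gives only a limit (< 2000 nM).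

Compound 4 `Cc1c(Cc2ccccc2)c(=O)c2cc(Cl)ccc2n1C` has not yet been measured. It differs from compound 3 by chloro in place of methoxy on an aromatic carbon. The same exchange has been seen once, as a number no higher from compound 1 to compound 2 (the limit leaves the size open) and this tells a direction but no size. The methyl step (a 5.0-fold higher number from compound 1 to compound 3 (0.70 log units; beyond the scatter)) does not bear on this exchange directly, since compound 3 and compound 4 both carry that methyl. A drop from compound 3 is therefore expected, of modest size, though it may not clear the scatter. The expected step is a 2.5-fold lower number from compound 3 to compound 4 (0.40 log units; beyond the scatter) and it remains an estimate. For compound 4 the estimated value is 4000 nM with an expected range from 1200 nM to 10000 nM and the assay may report only a limit.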

Compound 4, solubility: 2000 nM
Estimate against measurement, compound 4: 2.0-fold (0.30 log units) above; low and high end bracket the measured number.
By their numbers in this assay, from the lowest: compounds 1 and 4 (each within the scatter of the next); then compound 3.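

In this assay, within the data shown here, chloro in place of methoxy on an aromatic carbon now has a readable size for the first time, with a 5.0-fold lower number from compound 3 to compound 4 (0.70 log units; beyond the scatter). The earlier compounds shown here gave this exchange a direction only, whereas this pair shows that, with methyl on the aromatic nitrogen, the change at this place is large enough to stand clear of the scatter. Methyl in place of hydrogen on an aromatic nitrogen comes with a number no lower from compound 2 to compound 4 (the limit leaves the size open). The size of this step cannot be read, and neither can that of the earlier step from compound 1 to compound 2, since compound 2 carries a limit and not a number: the limit of < 2000 nM in this assay, at which 1 of the 4 values shown sits.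

Going by these compounds, the size therefore rests on this single pair, and whether it also holds with hydrogen on the aromatic nitrogen remains unknown. The compounds shown carry only methoxy or chloro at this aromatic carbon, so they leave open how a group such as an amine or a carboxylic acid at the same place would read in this assay.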